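Adding a third methoxy to a diaminoquinoxaline growth inhibitor

The compounds below may be only part of what the source reports. "The series", "measured", "known", "first", "only" and "open" are said of these compounds alone.

Measured so far:
compound 1 `Nc1cc(N)c2nc(-c3ccccc3)c(NCc3ccc(Cl)c(Cl)c3)nc2c1`: 52500 nM
compound 2 `COc1ccc(CNc2nc3cc(N)cc(N)c3nc2-c2ccccc2)cc1OC`: 24500 nM

In a functional assay on CAKI-1 cells (Homo sapiens) for inhibition, read by sulforhodamine B assay, with a stated time of 48 h (a lower number here means a stronger inhibitor of growth, a higher number a weaker inhibitor of growth), compound 2 gives 24500 nM, the lowest of the two numbers; its nearest neighbour is compound 1, with a 2.1-fold lower number from compound 1 to compound 2 (0.33 log units; beyond the scatter). Compound 3 `COc1cc(CNc2nc3cc(N)cc(N)c3nc2-c2ccccc2)cc(OC)c1OC` differs from compound 2 by methoxy in place of hydrogen on an aromatic carbon. Within the data shown here, no measured step covers this change: the only step, from dichlorophenyl to dimethoxyphenyl, was modest and concerns a different substitution. In this assay compound 3 is therefore expected to show no step beyond the scatter, a 1.0-fold lower number from compound 2 to compound 3 (0.01 log units; within the scatter). The estimate for compound 3 is 24000 nM, within 10000 nM to 60000 nM.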

Compound 3, concentration for total growth inhibition: 8710 nM
The estimate for compound 3 lay 2.8-fold (0.44 log units) above the measured number; the measured number lies below the stated range.
By their numbers in this assay, from the lowest: compound 3; then compound 2; then compound 1.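

In this assay the added methoxy gives a 2.8-fold lower number from compound 2 to compound 3 (0.45 log units; beyond the scatter), so this aromatic carbon, ortho to a methoxy group and meta to a large group, tolerates a further methoxy and the compound becomes a stronger growth inhibitor. The earlier pair showed only a swap of groups on the ring, not the effect of filling a position that held hydrogen. Nothing available explains this step. The compounds shown leave open whether a hydroxyl, an ethoxy or an amine at this carbon would match methoxy.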